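Swapping isopropyl for cyanomethyl on the amide nitrogen

The source may hold more compounds than are shown below. What is called first, only, known or untested is meant among the compounds shown, and "the series" means these compounds.

Compound 1 `Cc1ccc(Sc2cnc(Nc3ccccn3)s2)cc1C(N)=O`: 790 nM
Compound 2 `CCNC(=O)c1cc(Sc2cnc(Nc3ccccn3)s2)ccc1C`: limit, > 5000 nM
Compound 3 `Cc1ccc(Sc2cnc(Nc3ccccn3)s2)cc1C(=O)NC(C)C`: 2000 nM

In an assay on isolated protein for inhibition of high affinity nerve growth factor receptor (Homo sapiens) (on this read-out lower numbers stand for stronger inhibition and higher numbers for weaker inhibition), compound 3 gives 2000 nM. Among the numbers shown, compound 3 sits highest; compound 1 lies lower, a 2.5-fold higher number from compound 1 to compound 3 (0.40 log units; beyond the scatter). For compound 2 the read-out is only a limit of the assay, (the limit of > 5000 nM in this assay, at which 1 of the 3 values shown sits), and the comparison to compound 3 reads an at least 2.5-fold lower number from compound 2 to compound 3 (0.39 log units; beyond the scatter).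

The next change is cyanomethyl in place of isopropyl on an amide-type nitrogen, giving compound 4 `Cc1ccc(Sc2cnc(Nc3ccccn3)s2)cc1C(=O)NCC#N`. Every measured step here alters the group on that same amide nitrogen, and each moved the number by a modest amount or more: an at least 6.3-fold higher number from compound 1 to compound 2 (0.80 log units; beyond the scatter) and a 2.5-fold higher number from compound 1 to compound 3 (0.40 log units; beyond the scatter). Cyanomethyl is neither the bare hydrogen of compound 1 nor the ethyl of compound 2, so the direction is open. Compound 4 is therefore expected to give 2500 nM, within 800 nM to 8000 nM. That estimate means the expected step of a 1.3-fold higher number from compound 3 to compound 4 (0.10 log units; within the scatter) stays within the scatter.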

Compound 4, half-maximal inhibitory concentration: 44 nM
Compound 4: middle estimate off by 57-fold (1.75 log units), on the high side; the whole stated range lies above it.
By their numbers in this assay, from the lowest: compound 4; then compound 1; then compound 3. At a limit, above all of these: compound 2.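

Until now, every group placed on this amide-type nitrogen gave a higher number than the bare hydrogen of compound 1, but cyanomethyl reverses that in this assay, with an 18-fold lower number from compound 1 to compound 4 (1.25 log units; beyond the scatter) and a 45-fold lower number from compound 3 to compound 4 (1.66 log units; beyond the scatter) even though both groups have 3 heavy atoms. Against ethyl the change is also large, with an at least 110-fold lower number from compound 2 to compound 4 (2.05 log units; beyond the scatter) for this swap. Compound 2 gives only a limit: the limit of > 5000 nM in this assay, at which 1 of the 4 values shown sits.

The cause of the drop remains unknown. Also open, from the compounds shown here alone, is how a longer nitrile chain, such as cyanoethyl, or an amine or carboxylic acid on the chain would read.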